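Halogen for methoxy on the aroyl ring: compound 4

A few compounds are considered here, and "the series" means these few. Any claim that something is new, unique, unknown or untested is made for them only; others in the source may bear on it.

Measured in a functional assay on PC-3 cells (Homo sapiens) for cytotoxicity, read by MTT assay, with a stated time of 48 h; a higher number here means a weaker inhibitor, a lower number a stronger inhibitor:
Compound 1 `COc1ccc(C(=O)C2Sc3nnc(-c4cc(OC)c(OC)c(OC)c4)n3NC2c2ccco2)cc1` gives > 100000 nM, a limit of the assay and not a number.
Compound 2 `COc1ccc(C(=O)C2Sc3nnc(-c4cc(OC)c(OC)c(OC)c4)n3NC2c2cccs2)cc1` gives 95900 nM.
Compound 3 `COc1cc(-c2nnc3n2NC(c2cccs2)C(C(=O)c2ccc(Cl)cc2)S3)cc(OC)c1OC` gives 32500 nM.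

Compound 1 stands at the limit (the limit of > 100000 nM in this assay, at which 1 of the 3 values shown sits); only a limit is known for it. Compound 4 `COc1cc(-c2nnc3n2NC(c2ccco2)C(C(=O)c2ccc(Br)cc2)S3)cc(OC)c1OC` differs from compound 1 by bromo in place of methoxy on an aromatic carbon. The change an at least 1.0-fold lower number from compound 1 to compound 2 (0.01 log units; that floor lies within the scatter) hardly registers. The step of a 3.0-fold lower number from compound 2 to compound 3 (0.47 log units; beyond the scatter) is the closer guide: it also exchanges the methoxy on that aromatic carbon for a halogen and lowers the number modestly. A step of similar size and direction is expected here. Compound 4 is therefore estimated at 40000 nM, between 15000 nM and 150000 nM. That expectation corresponds to the step of an at least 2.5-fold lower number from compound 1 to compound 4 (0.39 log units; beyond the scatter), its true size uncertain since it starts from a limit.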

Compound 4, half-maximal inhibitory concentration: 36400 nM
Estimate against measurement, compound 4: 1.1-fold (0.04 log units) above, within the range that was stated.
By their numbers in this assay, from the lowest: compounds 3 and 4 (each within the scatter of the next); then compound 2. At a limit, above all of these: compound 1.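

Moving from (4-methoxyphenyl)carbonyl to (4-bromophenyl)carbonyl gives an at least 2.7-fold lower number from compound 1 to compound 4 (0.43 log units; beyond the scatter), so a halogen in place of methoxy on this aromatic carbon lowers the number with furan-2-yl on the saturated ring carbon, as it does with thiophen-2-yl. Bromo now joins chloro, but those two compounds differ in a second place and cannot be compared directly. Compound 1 is a limit and not a number, so this step is only a floor: the limit of > 100000 nM in this assay, at which 1 of the 4 values shown sits.

Still open, as far as these compounds go, is whether fluoro follows chloro and bromo on this carbon, and whether an amine or a carboxylic acid there would also lower the number.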